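A Second Chloro on the Benzyl Ring

The source may report more compounds than this note shows. Statements on the series, on what has been measured and on what is new or still open speak of the compounds shown alone.

Measured compounds:
compound 1 `Cc1ccc(COc2ccc(C(=O)NC(=S)Nc3ccc(C)c(-c4nc5ccccc5[nH]4)c3)cc2)cc1`: 60900 nM
compound 2 `Cc1ccc(NC(=O)NC(=O)c2ccc(OCc3cccc(Cl)c3)cc2)cc1-c1nc2ccccc2[nH]1`: 16000 nM

Both were tested in a functional assay on SW-620 cells (Homo sapiens) for inhibition, read by MTT assay, with a stated time of 48 h; on this read-out lower numbers stand for stronger inhibition and higher numbers for weaker inhibition. Compound 2 holds the lowest of the two numbers; compound 1 sits beyond the usual scatter above it. Among the measured compounds shown here, the two differ in more than one place, so no single step can be drawn between them, and only their two values can be compared.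

Compound 3 `Cc1ccc(NC(=O)NC(=O)c2ccc(OCc3cccc(Cl)c3Cl)cc2)cc1-c1nc2ccccc2[nH]1` is the next member. It differs from compound 2 by chloro in place of hydrogen on an aromatic carbon. For the measured compounds named here, no pair among the measured compounds isolates this change, so there is nothing to set a size against. With the rest of the molecule unchanged, the step from compound 2 to compound 3 in this assay is expected to be small, not beyond the scatter, with at most a slight lean towards a lower number; the expected step is a 1.3-fold lower number from compound 2 to compound 3 (0.12 log units; within the scatter). On that basis compound 3 is estimated at 12000 nM, with a range from 4000 nM to 40000 nM.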

Compound 3, half-maximal inhibitory concentration: 42100 nM
Estimate against measurement, compound 3: 3.5-fold (0.55 log units) below, and the stated range ends below it.
By their numbers in this assay, from the lowest: compound 2; then compounds 3 and 1 (each within the scatter of the next).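

In this assay the change from (3-chlorobenzyl)oxy to (2,3-dichlorobenzyl)oxy brings a 2.6-fold higher number from compound 2 to compound 3 (0.42 log units; beyond the scatter) and gives the series its first step that isolates a single change. It shows that this aromatic carbon, ortho to a chloro group and ortho to a large group, is not a neutral place for a chloro on this read-out: one added heavy atom moves the number modestly towards weaker inhibition, so a second chloro on the benzyl ring brings no gain here. No measurement available bears on why the number rises with this change.

As far as these compounds go, what remains open is whether this rise belongs to chloro itself or to any group at this carbon, since a fluoro, a methyl or a methoxy in the same place would separate those two readings. From the compounds shown here alone, it is also open whether the step depends on the chloro already present on the ring, and whether it would keep its direction and size in the thiourea series to which compound 1 belongs.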